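A few compounds are considered here, and "the series" means these few. Any claim that something is new, unique, unknown or untested is made for them only; others in the source may bear on it.

In an assay on isolated protein for inhibition of serine/threonine-protein kinase TNNI3K (Homo sapiens) (a higher number here means a weaker inhibitor, a lower number a stronger inhibitor), compound 2 `O=C(Nc1ccc(Oc2cc(O)ncn2)cc1)Nc1cccc(C(F)(F)F)c1` gives 3200 nM, the higher of the two plain numbers measured here. Compound 3 `CNc1cc(Oc2c(F)cc(NC(=O)Nc3cccc(C(F)(F)F)c3)cc2F)ncn1` gives 20 nM, a far lower number that lies beyond the scatter. For compound 1 `CCc1cc(NC(=O)Nc2cccc(C(F)(F)F)c2)cc(Cl)c1Oc1cc(NC)ncn1` the assay reports only a limit, <= 10 nM, which is the limit of <= 10 nM in this assay, at which 1 of the 3 values shown sits. Compound 4 `CC(C)(O)CNc1cc(Oc2ccc(NC(=O)Nc3cccc(C(F)(F)F)c3)cc2)ncn1` differs from compound 2 in a single place: (2-hydroxy-2-methylpropyl)amino in place of hydroxy on an aromatic carbon. Compound 3 carries an amino substituent on the shared core and gives 20 nM; compound 4 brings in an amino substituent of its own, so a strong move toward that number is expected. The estimated step from compound 2 to compound 4 is a 110-fold lower number from compound 2 to compound 4 (2.03 log units; beyond the scatter), a gain well beyond the scatter. Compound 4 is therefore expected to give about 30 nM, between 8 nM and 150 nM.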

Compound 4, half-maximal inhibitory concentration: 40 nM
The estimate for compound 4 lay 1.3-fold (0.12 log units) below the measured number; measured number inside the range.
By their numbers in this assay, from the lowest: compounds 3 and 4 (each within the scatter of the next); then compound 2. At a limit, below all of these: compound 1.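

Swapping hydroxy for (2-hydroxy-2-methylpropyl)amino on the aromatic carbon next to the ring nitrogen gives, in this assay, an 80-fold lower number from compound 2 to compound 4 (1.90 log units; beyond the scatter). Among the compounds shown here, this is the first direct reading of a change at this position, and it shows that the position accepts a much larger group than hydroxy, with a large gain. Nothing shown here explains why this change helps.

Going by these compounds, it remains open whether the gain comes from the amino nitrogen or from the chain and its hydroxy group. An unsubstituted amine, a longer chain without the hydroxy group or a carboxylic acid at this position would help separate these parts.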